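Fluoro to chloro on the aryl triazole acetamide

The source may report more compounds than this note shows. Statements on the series, on what has been measured and on what is new or still open speak of the compounds shown alone.

Measured so far in a functional assay on BMDM cells (Mus musculus, strain C57BL/6) for inhibition, with a stated time of 2 days; on this read-out higher numbers stand for weaker inhibition and lower numbers for stronger inhibition:
compound 1 `O=C(Cn1cc(-c2ccc(F)cc2)nn1)Nc1nc2ccccc2s1`: > 30000 nM
compound 2 `CCOC(=O)c1sc(NC(=O)Cn2cc(-c3ccc(OC)cc3)nn2)nc1C`: 2330 nM

In this assay compound 1 gives > 30000 nM; this is a limit of the assay and not a number. Going by the values given here, compound 2 gives 2330 nM in this assay, a measured number, and no single-change step links compound 2 to compound 1. Among the compounds with values here, the only point of evidence on the measured values is the limit of > 30000 nM in this assay, at which 1 of the 2 values shown sits.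

Compound 3 `O=C(Cn1cc(-c2ccc(Cl)cc2)nn1)Nc1nc2ccccc2s1` differs from compound 1 in one place: chloro in place of fluoro on an aromatic carbon. Within the data shown here, no step between measured compounds with this change is available, so the expectation rests on compound 1 alone. The step from compound 1 to compound 3 is expected to be small, in no set direction, and within the scatter: a number no higher from compound 1 to compound 3 (the limit leaves the size open). Compound 3 is estimated at 30000 nM, with a range from 10000 nM to 100000 nM, and it is expected that this assay most likely reports a limit again rather than a number.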

Compound 3, half-maximal inhibitory concentration: 130 nM
Compound 3: middle estimate off by 230-fold (2.36 log units), on the high side; the measured number lies below the stated range.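

In this assay, the change from 4-fluorophenyl to 4-chlorophenyl gives an at least 230-fold lower number from compound 1 to compound 3 (2.36 log units; beyond the scatter), so the halogen at this position, para to a large group, decides much of the read-out on this core. Going by these compounds alone, until now the series held no step at this position, and this is the first single-change comparison within it. Compound 1 gives > 30000 nM, a limit of the assay and not a number, which leaves the full size of the step unread: the limit of > 30000 nM in this assay, at which 1 of the 3 values shown sits.

On these data alone, whether this position takes other groups, such as bromo, methyl or trifluoromethyl, as well as chloro remains open, and so does the plain phenyl without any group there. Also open, as far as these compounds go, is how the methoxy group of compound 2 would read on the core of compound 3.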